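Adding a hydroxy group to the biphenyl of compound 3

The source may hold more compounds than are shown below. What is called first, only, known or untested is meant among the compounds shown, and "the series" means these compounds.

Measured so far:
compound 1 `CN(Cc1ccccc1O)c1ccc(C2CCCCC2)cc1` — "not active" (no number reported)
compound 2 `Cc1ccc(CNc2ccc(C3CCCCC3)cc2)c(O)c1` — "not active" (no number reported)
compound 3 `Oc1ccccc1CNc1ccc(-c2ccccc2)cc1` — 1820 nM

Within the data shown here, in a functional assay on Jurkat cells (Homo sapiens) for activation, with a stated time of 24 h (a lower number here means that less compound is needed, a higher number that more compound is needed for the effect), compound 3 is the only compound of the three with a reported number; compound 1 and compound 2 were each reported without one. Compound 3 is therefore the reference point for the next step.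

Compound 4 `Oc1ccc(-c2ccc(NCc3ccccc3O)cc2)cc1` is not yet measured. It differs from compound 3 in a single place: hydroxy in place of hydrogen on an aromatic carbon

Among the measured compounds shown here, no step between two measured compounds is available, so there is no direct precedent for this kind of change. A hydroxy group entering in place of hydrogen on an aromatic carbon is a small addition, and in this assay the expected step is small, most likely no change beyond the usual scatter, with a modest improvement or loss both possible. The step from compound 3 to compound 4 is expected to be a 1.2-fold lower number from compound 3 to compound 4 (0.08 log units; within the scatter). For compound 4 the estimate in this assay is 1500 nM, within a range from 400 nM to 6000 nM.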

Compound 4, half-maximal effective concentration: "not active" (no number reported)
For compound 4 the study gives words and no number; no gap can be computed for the estimate.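

In this assay, among these compounds, compound 4 is reported as "not active" (no number reported) without a number, and no step from compound 3 to compound 4 can be read. Nothing available here explains this result. The compounds shown leave open how far the change from phenyl to 4-hydroxyphenyl shifts the number, and whether other hydroxy placements keep a measurable effect.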